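This account rests on a few compounds, and the source may have more. Where it says the series, first, only, none or still open, it means among the compounds named here.

Measured compounds in an assay on isolated protein for inhibition of histone acetyltransferase p300 (Homo sapiens), with a stated time of 60 min; on this read-out lower numbers stand for stronger inhibition and higher numbers for weaker inhibition:
- compound 1 `COc1ccc(NC(=O)[C@H]2CCCN2C(=O)C(C)(C)c2ccc(Cl)cc2)cc1`: 50.1 nM
- compound 2 `O=C(Nc1ccc2[nH]ncc2n1)[C@H]1CCCN1C(=O)C1(c2cccc(Cl)c2)CCCC1`: 0.159 nM

Compound 2 gives the lowest number of the two; compound 1 is the nearest, and the gap between them lies beyond the scatter. Compound 3 `O=C(Nc1cnc2[nH]ncc2c1)[C@H]1CCCN1C(=O)C1(c2cccc(Cl)c2)CCCC1` keeps the same atoms as compound 2, joined differently: a group of 9 heavy atoms (6 carbon, 3 nitrogen; one five-membered aromatic ring with 2 hetero atoms, one six-membered aromatic ring with 1 hetero atom) in place of a group of 9 heavy atoms (6 carbon, 3 nitrogen; one five-membered aromatic ring with 2 hetero atoms, one six-membered aromatic ring with 1 hetero atom), on an amide-type nitrogen. Going by the values given here, no step between measured compounds speaks to this kind of change, so the direction is uncertain; a modest loss is expected, going from compound 2 to compound 3 by a 6.3-fold higher number from compound 2 to compound 3 (0.80 log units; beyond the scatter). In this assay compound 3 is expected at 1 nM, within 0.2 nM to 10 nM.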

Compound 3, half-maximal inhibitory concentration: 15.9 nM
Beside the measured number, compound 3's estimate is 16-fold (1.20 log units) below it; the whole stated range lies below it.
By their numbers in this assay, from the lowest: compound 2; then compound 3; then compound 1.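

On the amide-type nitrogen, the group keeps the same heavy-atom count, ring types, and donor and acceptor counts, yet this assay records a 100-fold higher number from compound 2 to compound 3 (2.00 log units; beyond the scatter). This position is therefore sensitive to how the atoms of the group are joined, not only to which atoms it holds. No measurement here accounts for the step.

From the compounds shown here alone, it remains open whether the same loss would appear with other groups on the rest of the molecule. Going by these compounds, it is also open how an amine or a methyl on the group at this nitrogen would shift the number.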